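The compounds below may be only part of what the source reports. "The series", "measured", "known", "first", "only" and "open" are said of these compounds alone.

Measured so far in an assay on cells for antagonist activity at transient receptor potential cation channel subfamily V member 1 (Homo sapiens), read by FLIPR and calcium flux, with a stated time of 6 min; on this read-out higher numbers stand for weaker inhibition and lower numbers for stronger inhibition:
compound 1 `CCCCCc1nc(C(C)(C)C)ccc1CNC(=O)C(C)c1ccc(NS(C)(=O)=O)c(F)c1` gives 1.9 nM;
compound 2 `CC(C(=O)NCc1ccc(C(C)(C)C)nc1C1CCCCC1)c1ccc(NS(C)(=O)=O)c(F)c1` gives 3.1 nM;
compound 3 `CCCCCc1cc(C(C)(C)C)ccc1CNC(=O)C(C)c1ccc(NS(C)(=O)=O)c(F)c1` gives 2.8 nM.

Compound 1 and compound 2 share one core, and the difference between them is cyclohexyl in place of pentyl on an aromatic carbon. That change made a step of a 1.6-fold higher number from compound 1 to compound 2 (0.21 log units; within the scatter). Compound 3 has a different core; the difference between the two cores is not broken down here. In this assay compound 3 sits close to compound 2, and all three values lie within the scatter of one another.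

Compound 4 `CC(C(=O)NCc1ccc(C(C)(C)C)cc1C1CCCCC1)c1ccc(NS(C)(=O)=O)c(F)c1` is not yet measured. It relates to compound 3 by cyclohexyl in place of pentyl on an aromatic carbon. This is the same kind of change as that from compound 1 to compound 2, but not the same: in the earlier pair the place is on a six-membered aromatic ring with one nitrogen, next to the ring nitrogen, whereas in compound 3 and compound 4 it is on a six-membered aromatic ring of carbon only.

Because the earlier step was a 1.6-fold higher number from compound 1 to compound 2 (0.21 log units; within the scatter), a step of about a 1.4-fold higher number from compound 3 to compound 4 (0.15 log units; within the scatter) is expected here. On that basis compound 4 is estimated at 4 nM, with a likely range from 1.5 nM to 11 nM.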

Compound 4, inhibition constant: 9.8 nM
Beside the measured number, compound 4's estimate is 2.5-fold (0.39 log units) below it; low and high end bracket the measured number.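

In this assay, cyclohexyl in place of pentyl on an aromatic carbon of a six-membered aromatic ring of carbon only gave a 3.5-fold higher number from compound 3 to compound 4 (0.54 log units; beyond the scatter), a step beyond the scatter, whereas the same change on the core of compound 1 stayed within it. Set side by side, the two steps cannot be told apart: the same change on two cores in this assay, a 1.6-fold higher number (0.21 log units; within the scatter) from compound 1 to compound 2 and a 3.5-fold higher number (0.54 log units; beyond the scatter) from compound 3 to compound 4, 2.1-fold (0.33 log units) apart, within the scatter of two such steps

The data therefore give no firm sign that the core alters what this change does, but they do not show that the step carries over unchanged, and two pairs set no rule for other cores.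

The compounds shown leave open whether a shorter chain such as propyl, a phenyl ring or a chain ending in an amine would behave like pentyl or cyclohexyl on either core. They also leave open whether the same comparison would hold with a group other than tert-butyl on the ring, such as trifluoromethyl.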